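Replacing 4-pentylphenyl with cyclopropyl on an aromatic carbon

This account rests on a few compounds, and the source may have more. Where it says the series, first, only, none or still open, it means among the compounds named here.

Among the compounds with values here, in a functional assay on HCT-116 cells (Homo sapiens) for antiproliferative activity, read by MTT assay, with a stated time of 72 h (on this read-out higher numbers stand for weaker inhibition and lower numbers for stronger inhibition), compound 2 `CCCCCc1ccc(-c2cn(C[C@H](O)[C@H]3OC(=O)C(OCc4ccccc4)=C3OCc3ccccc3)nn2)cc1` gives 13800 nM, the only actual number in this small set. Compound 1 `O=C1O/C(=C\Cn2cc(-c3cc(F)cc(F)c3)nn2)C(OCc2ccccc2)=C1OCc1ccccc1` gives > 100000 nM, which is a limit of the assay and not a number. Compound 3 `COc1ccc(-c2cn(C/C=C3\OC(=O)C(OCc4ccccc4)=C3OCc3ccccc3)nn2)cc1` gives > 100000 nM, which is also a limit.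

The next compound to be tested is compound 4 `O=C1O[C@H]([C@@H](O)Cn2cc(C3CC3)nn2)C(OCc2ccccc2)=C1OCc1ccccc1`, which differs from compound 2 in one group: cyclopropyl in place of 4-pentylphenyl on an aromatic carbon. Cyclopropyl thus enters where 4-pentylphenyl leaves, and the six-membered aromatic ring of carbon only leaves with it.

Within the data shown here, the one measured step is a step that the two limits leave unreadable from compound 1 to compound 3, and it offers no size to carry over. Among the measured compounds shown here, it also concerns a different pair of groups, so no measured step covers this change directly. For the measured compounds named here, the only guide is indirect. Neither compound 1 nor compound 3 carries 4-pentylphenyl, and both sit at the limit of > 100000 nM in this assay, at which 2 of the 3 values shown sit, although they also differ from compound 2 elsewhere in the structure. On that thin basis, weaker inhibition is the likelier direction in this assay, and a reading at the limit would be no surprise. The expected step is a 4.3-fold higher number from compound 2 to compound 4 (0.64 log units; beyond the scatter), estimated to lie beyond the usual scatter. For compound 4 the estimated value is 60000 nM, with an expected range of 20000 nM to 150000 nM.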

Compound 4, half-maximal inhibitory concentration: 30400 nM
Compound 4: middle estimate off by 2.0-fold (0.30 log units), on the high side; low and high end bracket the measured number.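

In this assay, within the data shown here, cyclopropyl in place of 4-pentylphenyl gives a 2.2-fold higher number from compound 2 to compound 4 (0.34 log units; beyond the scatter), the first step in this set with a size that can be read. At this aromatic carbon of the five-membered aromatic ring with 3 nitrogen, the six-membered aromatic ring of carbon only and the pentyl chain can both leave, and a group with fewer heavy atoms can stand in their place, at a modest cost in inhibition. Compound 4 gives a number and not a limit, whereas the step between the other two compounds still cannot be read: the limit of > 100000 nM in this assay, at which 2 of the 4 values shown sit.

From the compounds shown here alone, what a plain phenyl or a straight pentyl chain would give on this carbon stays open, and the step therefore cannot be divided between the aromatic ring and the chain of 4-pentylphenyl. Also open, going by these compounds, are how an amine or a carboxylic acid would read at this place in this assay, and whether the change from 4-pentylphenyl to cyclopropyl would give a step of similar size on the core of compound 1.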